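This account rests on a few compounds, and the source may have more. Where it says the series, first, only, none or still open, it means among the compounds named here.

Measured compounds in an assay on CHO cells for displacement of a labelled ligand from adenosine receptor A1 (Homo sapiens), tested at 10 uM; a lower number here means less inhibition, a higher number more inhibition at the concentration tested (going by the name of the read-out):
compound 1 `COc1ccc(C(=O)Nc2nn(-c3ccccc3)c(=O)c3ccccc23)cc1` gives 0%
compound 2 `O=C(Nc1ccccc1)Nc1nn(-c2ccccc2)c(=O)c2ccccc12` gives 44%
compound 3 `O=C(NCc1ccccc1)Nc1nn(-c2ccccc2)c(=O)c2ccccc12` gives 20%

Compound 3 stands second highest of the three numbers: nearest to it is compound 1, lower by a step beyond the scatter, and furthest is compound 2, higher by a step beyond the scatter. The unmeasured compound 4 `O=C(Nc1ccccc1Cl)Nc1nn(-c2ccccc2)c(=O)c2ccccc12` differs from compound 3 in one place, on the amide-type nitrogen whose other neighbour is the carbonyl carbon: 2-chlorophenyl in place of benzyl on an amide-type nitrogen.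

The step that bears most directly is a number 24 percentage points lower from compound 2 to compound 3 (beyond the scatter), in which benzyl replaced phenyl on that nitrogen and the number fell. Compound 4 runs that change back, phenyl-like again but carrying a chlorine. Both a number 44 percentage points higher from compound 1 to compound 2 (beyond the scatter) and a number 20 percentage points higher from compound 1 to compound 3 (beyond the scatter) likewise put the phenyl-bearing urea above the benzyl-bearing one. Within the data shown here, no measured step says what the chlorine on the ring does; that part is unknown. A rise beyond the scatter is therefore expected, roughly a number 20 percentage points higher from compound 3 to compound 4 (beyond the scatter), towards the level of compound 2. The estimate for compound 4 in this assay is 40%, with a range from 15% to 65%.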

Compound 4, a percentage reported as inhibition, at one concentration (the size of the read-out at that concentration, not a potency): 0%
Beside the measured number, compound 4's estimate is 40 percentage points above it; the measured number lies below the stated range.
By their numbers in this assay, from the lowest: compounds 1 and 4 (each within the scatter of the next); then compound 3; then compound 2.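

In this assay, a phenyl-type group on the amide-type nitrogen does not by itself hold the number up: chloro in place of hydrogen on an aromatic carbon gives a number 44 percentage points lower from compound 2 to compound 4 (beyond the scatter). The exchange of benzyl for 2-chlorophenyl gives a number 20 percentage points lower from compound 3 to compound 4 (beyond the scatter), so the earlier ranking of phenyl over benzyl at this nitrogen does not extend to the chlorinated ring. The urea link alone does not secure inhibition either, since (2-chlorophenyl)amino in place of 4-methoxyphenyl on the carbonyl carbon gives no change at the digits printed from compound 1 to compound 4 (within the scatter).

No measurement at hand accounts for the drop. As far as these compounds go, whether it follows chlorine itself or its place on the ring stays open, a question that 4-chlorophenyl, 3-chlorophenyl or 2-methylphenyl on the same nitrogen would address.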